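A few compounds are considered here, and "the series" means these few. Any claim that something is new, unique, unknown or untested is made for them only; others in the source may bear on it.

Of the compounds shown here, three from this series have been measured in a physicochemical assay for solubility, in phosphate buffer, measured as kinetic solubility, with a stated time of 1 h, at pH 7.4; a lower number here means a less soluble compound, a higher number a more soluble compound. Compound 1 `Cc1cc(C)cc(NC(=O)COc2cc(C)nc3ccc(C)cc23)c1` gives 83000 nM, and compound 2 `COc1ccc2nc(C)cc(OCc3ccc4ccccc4n3)c2c1` gives 21000 nM. Compound 3 `COc1ccc2nc(C)cc(OCC(=O)Nc3cccc(C)c3)c2c1` gives 193000 nM in this assay, the highest of the three numbers: compound 1 sits nearest, and compound 2 furthest, with both gaps beyond the usual scatter of repeated measurements.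

The step of interest leads from compound 3 to compound 4 `COc1ccc2nc(C)cc(OCC(=O)Nc3ccccn3)c2c1`, which has not yet been measured in this assay. The change is a single one: pyridin-2-yl in place of 3-methylphenyl on an amide-type nitrogen. A 3-methylphenyl group on an amide-type nitrogen gives way to a pyridin-2-yl group, so the six-membered ring loses its methyl and picks up one nitrogen in the ring, adding one hydrogen-bond acceptor.

Going by the values given here, no measured pair in this set shows this particular exchange, so the expectation rests on the size of the change alone. For compound 4 the step of a 1.3-fold higher number from compound 3 to compound 4 (0.11 log units; within the scatter) is expected to be small and upward, likely close to the edge of the scatter. Compound 4 is therefore estimated at 250000 nM, within a range from 110000 nM to 550000 nM.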

Compound 4, solubility: 29000 nM
Beside the measured number, compound 4's estimate is 8.6-fold (0.94 log units) above it; measured number below the stated range.
By their numbers in this assay, from the lowest: compounds 2 and 4 (each within the scatter of the next); then compound 1; then compound 3.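

Putting pyridin-2-yl in place of 3-methylphenyl on the amide-type nitrogen gives a 6.7-fold lower number from compound 3 to compound 4 (0.82 log units; beyond the scatter) in this assay and so moves the number beyond the scatter. Going by these compounds alone, this is the first step where only one place differs, and it shows that the group on this nitrogen can shift the read-out clearly. The swap removes the methyl and adds a ring nitrogen with its hydrogen-bond acceptor, yet the number goes down, not up, and nothing available here explains why.

The two parts of the change remain tangled, since a plain phenyl group on the same nitrogen would be needed to separate the loss of the methyl from the gain of the ring nitrogen. On these data alone, whether pyridin-3-yl there would behave like pyridin-2-yl also stays open.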